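Aryl urea end-group series: compound 3 to compound 4

A few compounds are considered here, and "the series" means these few. Any claim that something is new, unique, unknown or untested is made for them only; others in the source may bear on it.

Measured compounds:
compound 1 `Cc1ccc(NC(=O)Nc2cccc(CNc3nccnc3Cl)c2)cc1C` — 9870 nM
compound 2 `Cc1ccc(NC(=O)Nc2cccc(CNc3nccnc3Cl)c2)cc1` — 11900 nM
compound 3 `CCOc1ccc(NC(=O)Nc2cccc(CNc3nccnc3Cl)c2)cc1` — 7240 nM

All three share one core and differ only in the aryl group on the urea nitrogen. In a functional assay on MGC-803 cells (Homo sapiens) for antiproliferative activity, read by MTT assay, with a stated time of 48 h (on this read-out higher numbers stand for weaker inhibition and lower numbers for stronger inhibition), compound 3 stands at 7240 nM; compound 1 at 9870 nM and compound 2 at 11900 nM both sit within the scatter of that value, as the steps of a 1.4-fold lower number from compound 1 to compound 3 (0.13 log units; within the scatter) and a 1.6-fold lower number from compound 2 to compound 3 (0.22 log units; within the scatter) show.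

Compound 4 `O=C(Nc1ccccc1)Nc1cccc(CNc2nccnc2Cl)c1` is the next member. It differs from compound 3 as follows: hydrogen in place of ethoxy on an aromatic carbon.

Within the data shown here, two measured steps bear on this change, both on the same aryl ring: a 1.2-fold higher number from compound 1 to compound 2 (0.08 log units; within the scatter), and a 1.6-fold lower number from compound 2 to compound 3 (0.22 log units; within the scatter). Neither substituent swap on this ring has moved the number beyond the scatter, so taking the ethoxy away is expected to do little; if anything a slightly higher number, since the unsubstituted direction gave the higher values among the three.

Compound 4 is therefore estimated at 10000 nM, with a range from 4500 nM to 22000 nM. The expected step, a 1.4-fold higher number from compound 3 to compound 4 (0.14 log units; within the scatter), should stay within the scatter.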

Compound 4, half-maximal inhibitory concentration: 16300 nM
Beside the measured number, compound 4's estimate is 1.6-fold (0.21 log units) below it; the range from low to high includes it.
By their numbers in this assay, from the lowest: compounds 3, 1, 2 and 4 (each within the scatter of the next, the first and the last beyond it).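

In this assay, among these compounds, the step on taking away the ethoxy is the only one that passes the scatter (a 2.3-fold higher number from compound 3 to compound 4 (0.35 log units; beyond the scatter)), and it is modest; 4-ethoxyphenyl and phenyl on the urea nitrogen can thus be told apart, which no earlier pair allowed. The methyl-bearing compounds do not separate from phenyl in this way, as (a 1.4-fold higher number from compound 2 to compound 4 (0.14 log units; within the scatter)) and (a 1.7-fold higher number from compound 1 to compound 4 (0.22 log units; within the scatter)) both stay within the scatter. No measurement at hand gives a reason for the ethoxy step.

On these data alone, it remains open whether a methoxy, a longer butoxy chain or an amine at this place would hold the number near that of compound 3 (7240 nM). As far as these compounds go, it also remains open whether the oxygen or the chain carries the step.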